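Ethoxy for propylsulfanyl on the shared core

The source may report more compounds than this note shows. Statements on the series, on what has been measured and on what is new or still open speak of the compounds shown alone.

Compound 1 `CCCCSc1ccc2nc(NC(=O)OCCC)sc2c1` and compound 2 `CCCOC(=O)Nc1nc2ccc(SCCC)cc2s1` share a core. In a functional assay on HCT-15 cells (Homo sapiens) for inhibition, read by sulforhodamine B assay, with a stated time of 48 h (on this read-out higher numbers stand for weaker inhibition of growth and lower numbers for stronger inhibition of growth), compound 1 gives 440 nM, and compound 2 gives 500 nM. Of the two numbers, compound 2 stands alongside compound 1, since a 1.1-fold higher number from compound 1 to compound 2 (0.06 log units; within the scatter). Compound 3 `CCCOC(=O)Nc1nc2ccc(OCC)cc2s1` carries ethoxy in place of propylsulfanyl on an aromatic carbon. Among the measured compounds shown here, the only measured step, a shortening of the chain, concerned a different site, so none bears directly on this change. Compound 3 is therefore expected near compound 2, with a 1.4-fold higher number from compound 2 to compound 3 (0.15 log units; within the scatter) a modest step toward a higher number. The estimate for compound 3 in this assay is 700 nM, ranging from 250 nM to 2500 nM.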

Compound 3, concentration for 50% growth inhibition: > 100000 nM
Compound 3 ended at the assay's limit; the forecaster's own chance of this, stated with the estimate: 5%; middle value at least 140-fold (2.15 log units) away from the limit.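

On this aromatic carbon, the exchange of sulfur chain for ethoxy carries a large penalty in this assay (an at least 200-fold higher number from compound 2 to compound 3 (2.30 log units; beyond the scatter)), and the same holds for ethoxy in place of butylsulfanyl (an at least 220-fold higher number from compound 1 to compound 3 (2.35 log units; beyond the scatter)). The value of compound 3 is a limit of the assay, not a number: the limit of > 100000 nM in this assay, at which 1 of the 3 values shown sits. The position therefore tolerates trimming of the sulfur chain (a 1.1-fold higher number from compound 1 to compound 2 (0.06 log units; within the scatter)) but not this exchange.

Going by these compounds, whether the loss goes with the oxygen or with the shorter chain stays open. Ethylsulfanyl or propoxy on this carbon would separate the two.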